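Replacing an Aromatic End Group with Cyclopentyl

The compounds below may be only part of what the source reports. "The series", "measured", "known", "first", "only" and "open" are said of these compounds alone.

Going by the values given here, only two compounds with this shared core have numbers so far in a functional assay on HL-60 cells (Homo sapiens) for cytotoxicity, read by WST assay, with a stated time of 48 h (a higher number here means a weaker inhibitor, a lower number a stronger inhibitor), and they cannot be told apart. Among the compounds with values here, compound 1 (`O[C@@H](c1ccccc1)[C@H]1CO[C@H](c2ccccc2)[C@@H](C/C=C/c2ccccc2)C1`) gives 7040 nM and compound 2 (`O=[N+]([O-])c1cccc(/C=C/C[C@H]2C[C@@H]([C@@H](O)c3ccccc3)CO[C@@H]2c2ccccc2)c1`) gives 6350 nM on the same scale, which places compound 2 within the usual scatter of its only neighbour. Within the data shown here, the one measured step, nitro in place of hydrogen on an aromatic carbon, gives a 1.1-fold lower number from compound 1 to compound 2 (0.04 log units; within the scatter) as its result.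

Compound 3 (`O[C@@H](c1ccccc1)[C@H]1CO[C@H](c2ccccc2)[C@@H](C/C=C/C2CCCC2)C1`) is still unmeasured. Its change from compound 2 is larger (cyclopentyl in place of 3-nitrophenyl on a double-bonded chain carbon bound to a double-bonded chain carbon) and in words is cyclopentyl in place of 3-nitrophenyl on a double-bonded chain carbon bound to a double-bonded chain carbon. Among the measured compounds shown here, the measured step bears on this only loosely: it altered the aromatic ring without removing it, and no measured compound lacks that ring. For the measured compounds named here, with only that evidence, no step beyond the scatter is expected in this assay and no direction can be favoured, although the uncertainty is wide. The expected change is a 1.1-fold higher number from compound 2 to compound 3 (0.04 log units; within the scatter) and no more can be claimed. Compound 3 is expected to give 7000 nM (estimated range 3000 nM to 16000 nM).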

Compound 3, half-maximal inhibitory concentration: 9060 nM
Compound 3: middle estimate off by 1.3-fold (0.11 log units), on the low side, within the range that was stated.
By their numbers in this assay, from the lowest: compounds 2, 1 and 3 (each within the scatter of the next).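

Until now, every measured compound carried an aromatic ring on a double-bonded chain carbon bound to a double-bonded chain carbon, so the ring itself had never been tested. Compound 3 has cyclopentyl there, a five-membered non-aromatic ring of carbon only, and in this assay the result is a 1.4-fold higher number from compound 2 to compound 3 (0.15 log units; within the scatter), and against the unsubstituted parent it is a 1.3-fold higher number from compound 1 to compound 3 (0.11 log units; within the scatter). Neither step can be told from the scatter, so among these three compounds an aromatic ring at this place is not required for a number in this range, and the swap from 3-nitrophenyl to cyclopentyl, which also removes the two hydrogen-bond acceptors, leaves the compounds indistinguishable; no measurement here accounts for this result.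

The compounds shown all keep a carbon ring at the end of the chain, so it remains open whether a simple methyl, a longer chain with no ring, or no end group at all would give a similar number. As far as these compounds go, it is also open whether an amine or a carboxylic acid at this place would produce a step beyond the scatter, in either direction.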